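A few compounds are considered here, and "the series" means these few. Any claim that something is new, unique, unknown or untested is made for them only; others in the source may bear on it.

In an ADME assay on MCF7-DOX cells (Homo sapiens) for cytotoxicity, read by MTT assay, with a stated time of 48 h (on this read-out higher numbers stand for weaker inhibition and lower numbers for stronger inhibition), compound 3 (`CCCCCc1c(OC)cc(OC)c(C(=O)/C=C/c2cccc(N3CCNCC3)c2)c1O`) gives > 100000 nM as its reading, which is a limit of the assay and not a number. Compound 2 (`CCCc1c(OC)cc(OC)c(C(=O)/C=C/c2cccc(N3CCNCC3)c2)c1O`) gives > 100000 nM and this too is a limit. Compound 3 therefore stands at the limit of > 100000 nM in this assay, at which 2 of the 3 values shown sit, and has no exact position. For the measured compounds named here, the one measured step along this chain, a step that the two limits leave unreadable from compound 2 to compound 3, gives no size to build on.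

Compound 4 (`COc1cc(OC)c(C(=O)/C=C/c2cccc(N3CCNCC3)c2)c(O)c1CC=C(C)C`) differs from compound 3 in one place, 2-methylprop-1-en-1-yl in place of butyl on a saturated chain carbon bound to an aromatic carbon and, read one bond further out, the change is pentyl to 3-methylbut-2-en-1-yl. Compound 1 (`COc1cccc(/C=C/C(=O)c2c(OC)cc(OC)c(CC=C(C)C)c2O)c1`) carries that same 3-methylbut-2-en-1-yl chain and differs from compound 4 elsewhere, and in this assay compound 1 gives 49200 nM as a true number. That reading leaves room for a modest gain, though a result at the limit also remains likely. The expected step, an at least 1.2-fold lower number from compound 3 to compound 4 (0.09 log units; that floor lies within the scatter), is small and, if readable at all, runs toward stronger inhibition. For compound 4 the estimated value is 80000 nM with an expected range from 35000 nM to 100000 nM in this assay as the test.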

Compound 4, half-maximal inhibitory concentration: 99900 nM
Compound 4: middle estimate off by 1.2-fold (0.10 log units), on the low side; measured number inside the range.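

In this assay, the 3-methylbut-2-en-1-yl chain in place of pentyl gives a number no higher from compound 3 to compound 4 (the limit leaves the size open). Compound 4 reads 99900 nM, a true number rather than a limit. 2-Methylprop-1-en-1-yl in place of ethyl on a saturated chain carbon bound to an aromatic carbon gives a number no higher from compound 2 to compound 4 (the limit leaves the size open). On these data alone, compound 2 and compound 3 each stay at a limit of the assay, so the steps from them to compound 4 cannot be read and their size stays open: the limit of > 100000 nM in this assay, at which 2 of the 4 values shown sit. With the 3-methylbut-2-en-1-yl chain held constant, piperazin-1-yl in place of methoxy on an aromatic carbon gives a 2.0-fold higher number from compound 1 to compound 4 (0.31 log units; beyond the scatter), a modest move toward weaker inhibition.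

The compounds shown leave open whether a morpholin-4-yl group or a simple aminomethyl group on that aromatic carbon would stay closer to compound 1. They also leave open how a longer chain with a double bond, such as 3,7-dimethylocta-2,6-dien-1-yl, would read in place of the 3-methylbut-2-en-1-yl chain.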